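This account rests on a few compounds, and the source may have more. Where it says the series, first, only, none or still open, it means among the compounds named here.

- compound 1 `CC(C)(C)C(=O)OCC1(CO)C/C(=C\CCCCCCCCCCCCCCC=O)C(=O)O1` gives > 10 ug/mL (a limit, not a number)
- compound 2 `CC(=O)OCCCCCCCCCCCCCCC/C=C1\CC(CO)(COC(=O)C(C)(C)C)OC1=O` gives 5.62 ug/mL
- compound 3 `CC(C)(C)C(=O)OCCCCCCCCCCCCCCC/C=C1\CC(CO)(COC(=O)C(C)(C)C)OC1=O` is not yet measured

Among the measured compounds shown here, in a functional assay on SK-MEL-5 cells (Homo sapiens) for antiproliferative activity (on this read-out higher numbers stand for weaker inhibition of growth and lower numbers for stronger inhibition of growth), compound 2 gives 5.62 ug/mL as the only true number so far. The change leading to compound 3 is tert-butyl in place of methyl on a carbonyl carbon. For the measured compounds named here, the only measured step (an at least 1.7-fold lower number from compound 1 to compound 2 (0.25 log units; that floor lies within the scatter)) replaced formyl with the acetoxymethyl group now altered. Its floor lies within the scatter, so it sets no size for this change, and no step beyond the scatter is expected in this assay in either direction. The expected step (a 1.1-fold higher number from compound 2 to compound 3 (0.03 log units; within the scatter)) stays within the scatter. Compound 3 is estimated at 6 ug/mL with an expected range from 3 ug/mL to 12 ug/mL for now.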

Compound 3, concentration for 50% growth inhibition: 3.46 ug/mL
Estimate against measurement, compound 3: 1.7-fold (0.24 log units) above, and the stated range covers the measured number.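

In this assay, tert-butyl in place of methyl on a carbonyl carbon gives a 1.6-fold lower number from compound 2 to compound 3 (0.21 log units; within the scatter), so the larger group in this place brings no change that can be told from the scatter. Among the compounds shown here, replacing formyl with (((tert-butyl)carbonyl)oxy)methyl gives an at least 2.8-fold lower number from compound 1 to compound 3 (0.46 log units; beyond the scatter), the first step that clears the scatter. Compound 1 stands at a limit, not a number: the limit of > 10 ug/mL in this assay, at which 1 of the 3 values shown sits.

Going by these compounds, whether a carboxylic acid or an amine in place of the ester would hold this level stays open. So does the effect of a longer chain.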